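The source may report more compounds than this note shows. Statements on the series, on what has been measured and on what is new or still open speak of the compounds shown alone.

Measured compounds in a functional assay on the whole organism for positive allosteric modulation, with Mus musculus as the target; a lower number here means that less compound is needed, a higher number that more compound is needed for the effect:
compound 1, `CCC(=O)N(c1ccc(Cl)cc1)C1CCCC1N(C)C`: 3 mg/kg
compound 2, `CCC(=O)N(c1cccc(F)c1)C1CCCC1N(C)C`: 0.4 mg/kg
compound 3, `CCC(=O)N(c1ccc(F)cc1)C1CCCC1N(C)C`: 5 mg/kg

Not yet measured: compound 4, `CCC(=O)N(c1cccc(Cl)c1)C1CCCC1N(C)C`.

Compound 2 gives the lowest of the three numbers; compound 1 is its nearest neighbour and compound 3 stands furthest from it, both gaps lying beyond the scatter. Compound 2 and compound 3 have the same atoms joined differently; the difference between the two cores is not broken down here.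

One change recurs in the series. From compound 3 to compound 1 the step is a 1.7-fold lower number from compound 3 to compound 1 (0.22 log units; within the scatter), with the change (chloro in place of fluoro on an aromatic carbon). Compound 4 carries the same kind of change relative to compound 2, namely (chloro in place of fluoro on an aromatic carbon); the place is not identical, since in the measured pair the group sits para to a large group, whereas in the new pair it sits meta to a large group. Among the compounds with values here, only this one measured instance exists, and it lies within the scatter, so the expectation for compound 4 rests on that single step together with the value of compound 2. The step expected in this assay is a 1.3-fold lower number from compound 2 to compound 4 (0.12 log units; within the scatter), of a size like the measured one. Compound 4 is therefore estimated at 0.3 mg/kg, with a range from 0.1 mg/kg to 0.9 mg/kg, the width reflecting that the change is known only once and at a different place.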

Compound 4, dose for half-maximal effect: 0.4 mg/kg
Estimate against measurement, compound 4: 1.3-fold (0.12 log units) below; measured number inside the range.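

In this assay, chloro in place of fluoro on an aromatic carbon meta to a large group gives no change at the digits printed from compound 2 to compound 4 (within the scatter), so compound 2 and compound 4 cannot be told apart at this place. Set beside the same exchange on the other core, the step carries over with no difference that can be read between the two instances: the same change on two cores in this assay, a 1.7-fold lower number (0.22 log units; within the scatter) from compound 3 to compound 1 and no change at the digits printed (within the scatter) from compound 2 to compound 4, 1.7-fold (0.22 log units) apart, within the scatter of two such steps

Within the data shown here, this supports treating chloro and fluoro as interchangeable on the aromatic ring of these two cores in this assay, but it rests on only two pairs, with the group at a different place in each, and neither step lies beyond the scatter. It therefore shows that a near-absent step recurs, not that a step of real size would carry from one core to another, and it says nothing about any core beyond these two.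

Still open, on these data alone, is whether a group other than a halogen, such as methoxy, trifluoromethyl or nitrile, on the same aromatic carbon would keep the number near that of compound 2 or compound 4. Equally open, as far as these compounds go, are the effects of a longer chain on the carbonyl and of a larger amine in place of the dimethylamino group.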